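Propyl for Methyl on the Amide of Compound 1

This account rests on a few compounds, and the source may have more. Where it says the series, first, only, none or still open, it means among the compounds named here.

compound 1: `CNC(=O)c1cc(Oc2ccc(NC(=O)c3cc4cccnc4n(-c4ccc(Cl)cc4)c3=O)cc2)ccn1` — 390 nM
compound 2: `CNC(=O)c1cc(Oc2ccc(NC(=O)c3cc4cccnc4n(-c4ccc(Br)cc4)c3=O)cc2)ccn1` — 1180 nM
compound 3: `CNC(=O)c1cc(Oc2ccc(NC(=O)c3cc4cccnc4n(-c4ccc(F)c(Cl)c4)c3=O)cc2)ccn1` — 1810 nM

Of the compounds shown here, three have been measured in a functional assay on HT-29 cells (Homo sapiens) for antiproliferative activity, read by MTT assay, with a stated time of 72 h; a higher number here means a weaker inhibitor, a lower number a stronger inhibitor. Among them compound 1 gives the lowest number. The step of a 3.0-fold higher number from compound 1 to compound 2 (0.48 log units; beyond the scatter) and the step of a 4.6-fold higher number from compound 1 to compound 3 (0.67 log units; beyond the scatter) both lie beyond the scatter, whereas the step of a 1.5-fold higher number from compound 2 to compound 3 (0.19 log units; within the scatter) lies within it, so compound 2 and compound 3 cannot be told apart on these numbers.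

Compound 4, `CCCNC(=O)c1cc(Oc2ccc(NC(=O)c3cc4cccnc4n(-c4ccc(Cl)cc4)c3=O)cc2)ccn1`, differs from compound 1 by ethyl in place of hydrogen on a saturated chain carbon bound to an amide-type nitrogen. All three measured steps concern the aryl group on the aromatic nitrogen of the shared core, and none of them changes the methylcarbamoyl group. Going by the values given here, no measured step therefore bears on the change from compound 1 to compound 4, and the size of the step in this assay cannot be read from the measured pairs.

With nothing comparable to lean on, the expected step of a 1.3-fold higher number from compound 1 to compound 4 (0.11 log units; within the scatter) is set close to no change beyond the scatter, and a wide range is allowed for the possibility that the longer chain does matter. Compound 4 is accordingly estimated at 500 nM, between 150 nM and 1600 nM.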

Compound 4, half-maximal inhibitory concentration: 390 nM
For compound 4 the middle estimate is 1.3-fold (0.11 log units) above the measured one; the range from low to high includes it.
By their numbers in this assay, from the lowest: compounds 1 and 4 (each within the scatter of the next); then compounds 2 and 3 (each within the scatter of the next).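

In this assay the replacement of methylcarbamoyl by propylcarbamoyl gives no change at the digits printed from compound 1 to compound 4 (within the scatter) and so leaves compound 1 and compound 4 indistinguishable. Going by these compounds alone, this is the only reading in the set at this position, on a saturated chain carbon bound to an amide-type nitrogen, and it shows that here methyl can give way to propyl with no change beyond the scatter, whereas two of the three earlier steps, all of them on the aryl group on the aromatic nitrogen, lay beyond it. No measurement at hand speaks to what lies behind this result.

The compounds shown leave open how far this holds, since a single propyl chain says nothing about a longer chain such as butyl or hexyl, a branched isopropyl group, a cyclopropyl ring, or a chain ending in an amine or a carboxylic acid. They also leave open whether propyl in place of methyl would give the same outcome with the 4-bromophenyl group of compound 2 or the 3-chloro-4-fluorophenyl group of compound 3.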